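The source may report more compounds than this note shows. Statements on the series, on what has been measured and on what is new or still open speak of the compounds shown alone.

Compound 3 `C=C1[C@@H](OC(C)=O)C[C@@H]2[C@](C)(CO[Si](C)(C)C(C)(C)C)[C@H](OC(C)=O)CC[C@@]2(C)[C@@H]1C[C@@H](Nc1cccc2ccccc12)C1=CCOC1=O` is one of three analogues of a shared core examined in a functional assay on A549 cells (Homo sapiens) for cytotoxicity, read by sulforhodamine B assay; on this read-out lower numbers stand for stronger inhibition and higher numbers for weaker inhibition. Compound 3 gives 4970 nM, which places it second highest of the three numbers. Compound 2 `C=C1[C@@H](OC(C)=O)C[C@@H]2[C@](C)(CO[Si](C)(C)C(C)(C)C)[C@H](OC(C)=O)CC[C@@]2(C)[C@@H]1C[C@@H](Nc1ccc(C(=O)O)cc1)C1=CCOC1=O` gives 4210 nM, and the two sit close together: a 1.2-fold higher number from compound 2 to compound 3 (0.07 log units; within the scatter). Compound 1 `C=C1[C@@H](OC(C)=O)C[C@@H]2[C@](C)(COC=O)[C@H](OC(C)=O)CC[C@@]2(C)[C@@H]1C[C@@H](Nc1ccccc1C(=O)O)C1=CCOC1=O` carries a formate ester where compounds 2 and 3 carry a tert-butyldimethylsilyl ether. In this assay compound 1 gives 45900 nM, far above the other two.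

Compound 4 `C=C1[C@@H](OC(C)=O)C[C@@H]2[C@](C)(CO[Si](C)(C)C(C)(C)C)[C@H](OC(C)=O)CC[C@@]2(C)[C@@H]1C[C@@H](Nc1ccccc1C(=O)O)C1=CCOC1=O` is the next compound. It keeps the tert-butyldimethylsilyl ether of compound 3 and changes the group on the amine nitrogen: 2-carboxyphenyl in place of naphthalen-1-yl on an amine nitrogen. Going by the values given here, the only step measured at this position, from compound 2 to compound 3, stayed within the scatter, so swapping one aromatic group for another on this nitrogen has so far changed little. Among the compounds with values here, no measured step covers a 2-carboxyphenyl group against the silyl-ether background; compound 1 carries that group but differs from compound 4 elsewhere, so its high number cannot be attributed to the aromatic group alone.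

Compound 4 is therefore expected to stay near compound 3, with a step of a 1.2-fold higher number from compound 3 to compound 4 (0.08 log units; within the scatter) that is expected to fall within the scatter. The estimate for compound 4 in this assay is 6000 nM, with a range from 2500 nM to 20000 nM.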

Compound 4, half-maximal inhibitory concentration: 4890 nM
The estimate for compound 4 lay 1.2-fold (0.09 log units) above the measured number, within the range that was stated.
By their numbers in this assay, from the lowest: compounds 2, 4 and 3 (each within the scatter of the next); then compound 1.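

In this assay the step of a 1.0-fold lower number from compound 3 to compound 4 (0.01 log units; within the scatter) and the step of a 1.2-fold higher number from compound 2 to compound 4 (0.07 log units; within the scatter) both stay within the scatter, so the amine nitrogen now tolerates three different aromatic groups with no readable difference, and the carboxylic acid on the phenyl ring can appear as either 2-carboxyphenyl or 4-carboxyphenyl without a readable change. Going by these compounds alone, compound 4 also gives the first clean comparison at the other site, since it shares 2-carboxyphenyl with compound 1 and differs only in the group on the oxygen: the step of a 9.4-fold lower number from compound 1 to compound 4 (0.97 log units; beyond the scatter) lies beyond the scatter as the formate gives way to the tert-butyldimethylsilyl group. The high number of compound 1 therefore goes with its formate and not with its aromatic group.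

On these data alone, this rests on a single pair, so whether the same step appears with naphthalen-1-yl or 4-carboxyphenyl on the nitrogen remains open. Also open, as far as these compounds go, are a free hydroxyl at the silyl ether site, a methyl ester in place of the carboxylic acid and a plain saturated chain such as cyclohexyl on the amine nitrogen. Nothing available here offers an explanation for these results.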